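A few compounds are considered here, and "the series" means these few. Any claim that something is new, unique, unknown or untested is made for them only; others in the source may bear on it.

The measured compounds, with their values in a functional assay on HCT-116 cells (Homo sapiens) for cytotoxicity, read by MTT assay, with a stated time of 72 h; a lower number here means a stronger inhibitor, a higher number a weaker inhibitor:

Compound 1, `COc1cc(Nc2nc3ccccc3nc2S(=O)(=O)c2ccccc2)cc(OC)c1`, gives 950 nM.
Compound 2, `COc1cc(Nc2nc3ccccc3nc2S(=O)(=O)c2ccccc2)cc(OC)c1OC`, gives only a limit of the assay, > 50000 nM.
Compound 3, `COc1ccc(S(=O)(=O)c2nc3ccccc3nc2Nc2ccccc2)cc1`, gives 1260 nM.

Compound 1 and compound 3 differ by more than a single group; the difference between the two cores is not broken down here. Their two numbers lie within the usual scatter of each other, so no order between them can be claimed.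

Compound 1 and compound 2 differ in one place: methoxy in place of hydrogen on an aromatic carbon. This change made an at least 52-fold higher number from compound 1 to compound 2 (1.72 log units; beyond the scatter). The value of compound 2 is a limit, (the limit of > 50000 nM in this assay, at which 1 of the 3 values shown sits), so the true loss may be larger still.

Compound 4, `COc1ccc(Nc2nc3ccccc3nc2S(=O)(=O)c2ccc(OC)cc2)cc1`, has not yet been measured. It differs from compound 3 by the same kind of change: methoxy in place of hydrogen on an aromatic carbon. The place is not the same, though. In compound 2 the new methoxy stands ortho to two methoxy groups and para to a large group, whereas in compound 4 it stands only para to a large group, with no methoxy groups around it.

For the measured compounds named here, the expectation rests on compound 3 at 1260 nM and on the only measured example of this kind of change, an at least 52-fold higher number from compound 1 to compound 2 (1.72 log units; beyond the scatter), which was made in a place ortho to two methoxy groups and is therefore only a weak guide here. A smaller step toward a weaker inhibitor is expected, and it is estimated to come out as a 2.0-fold higher number from compound 3 to compound 4 (0.30 log units; within the scatter). Compound 4 is expected to give about 2500 nM, within a range from 700 nM to 15000 nM.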

Compound 4, half-maximal inhibitory concentration: 29100 nM
The estimate for compound 4 lay 12-fold (1.07 log units) below the measured number; the measured number lies above the stated range.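

In this assay, turning the anilino of compound 3 into the (4-methoxyphenyl)amino of compound 4 gave a large move toward a weaker inhibitor, with a 23-fold higher number from compound 3 to compound 4 (1.36 log units; beyond the scatter). Methoxy in place of hydrogen on an aromatic carbon therefore pushed the number the same way on both cores, although the surroundings of the new group were not the same in the two pairs: the same change on two cores in this assay, an at least 52-fold higher number (1.72 log units; beyond the scatter) from compound 1 to compound 2 and a 23-fold higher number (1.36 log units; beyond the scatter) from compound 3 to compound 4; the limit leaves it open whether they differ. Two pairs show a shared direction and no more; they do not tell whether the size of the step carries from one core to another or what the change would do at other places in the series, and the value of compound 2 remains a limit of the assay: the limit of > 50000 nM in this assay, at which 1 of the 4 values shown sits.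

From the compounds shown here alone, every group added in these steps is a methoxy, so it remains open whether fluorine, chlorine or methyl in the place para to a large group would bring a step of similar size. Going by these compounds, it also remains open how an amine or a carboxylic acid in that place would read in this assay, and whether either would move the number in the same direction as methoxy.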